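The source may report more compounds than this note shows. Statements on the series, on what has been measured and on what is new or still open speak of the compounds shown alone.

Measured so far in an ADME assay on PANC-1 cells (Homo sapiens) for cytotoxicity, read by sulforhodamine B assay, with a stated time of 48 h, tested at 10 uM; a lower number here means less inhibition, a higher number more inhibition at the concentration tested (going by the name of the read-out):
compound 1 `CCCCc1cn(C(c2ccccc2)c2cc3cc(Br)ccc3nc2OC)nn1` gives 5.46%
compound 2 `COc1nc2ccc(Br)cc2cc1C(c1ccccc1)n1cc(-c2ccc(Br)cc2)nn1` gives 10.4%
compound 3 `COc1nc2ccc(Br)cc2cc1C(c1ccccc1)n1cc(-c2cccc(F)c2)nn1` gives 15.5%

Among these three numbers compound 2 stands second highest. Its nearest neighbour is compound 1, with the step of a number 4.9 percentage points higher from compound 1 to compound 2 (within the scatter), and its furthest is compound 3, with the step of a number 5.1 percentage points higher from compound 2 to compound 3 (within the scatter); the remaining step, a number 10 percentage points higher from compound 1 to compound 3 (within the scatter), is likewise within the scatter. So far every swap of the group on the five-membered ring has left the read-out essentially unchanged.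

Compound 4 `CCOC(=O)c1cn(C(c2ccccc2)c2cc3cc(Br)ccc3nc2OC)nn1` is the next member. Compared with compound 2 the change is ethoxycarbonyl in place of 4-bromophenyl on an aromatic carbon. From the compounds shown here alone, all three measured steps bear on it in the sense that they exchange the group at the same place, and each was small; none of them, however, brings in ethoxycarbonyl, so the new group is untested here. On that basis the step of a number 0.4 percentage points lower from compound 2 to compound 4 (within the scatter) is expected to stay within the scatter. Compound 4 is therefore estimated at 10%, in the range 1% to 24%.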

Compound 4, a percentage reported as inhibition, at one concentration (the size of the read-out at that concentration, not a potency): 15.4%
Estimate against measurement, compound 4: 5.4 percentage points below; the range from low to high includes it.
By their numbers in this assay, from the lowest: compounds 1, 2, 4 and 3 (each within the scatter of the next).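

Ethoxycarbonyl brings hydrogen-bond acceptors and a double bond outside aromatic rings to this carbon of the five-membered ring, features that 4-bromophenyl lacks, yet in this assay the exchanges give a number 5 percentage points higher from compound 2 to compound 4 (within the scatter) and a number 0.1 percentage points lower from compound 3 to compound 4 (within the scatter) and also a number 9.9 percentage points higher from compound 1 to compound 4 (within the scatter) in this small set. For the compounds shown here, the read-out therefore stays within the scatter not only across butyl and the two substituted phenyl groups but also with this non-aromatic, oxygen-containing group, and no compound here stands apart from the others. Nothing available explains this flat picture. From the compounds shown here alone, whether a carboxylic acid, an amide or a primary amine at the same carbon would move the read-out beyond the scatter remains open. With a single tested concentration, these compounds also leave open how their potencies compare.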